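The source may hold more compounds than are shown below. What is called first, only, known or untested is meant among the compounds shown, and "the series" means these compounds.

Of the compounds shown here, three built on one shared core have been measured in a functional assay on TK-10 cells (Homo sapiens) for inhibition, read by sulforhodamine B assay, with a stated time of 48 h; on this read-out higher numbers stand for weaker inhibition of growth and lower numbers for stronger inhibition of growth. Compound 1 `Nc1cc(N)c2nc(-c3ccccc3)c(NCc3ccc(Cl)c(Cl)c3)nc2c1` gives 12900 nM in this assay, compound 2 `COc1ccc(CNc2nc3cc(N)cc(N)c3nc2-c2ccccc2)cc1OC` gives 16600 nM, and compound 3 `Nc1cc(N)c2nc(-c3ccccc3)c(NCc3ccc(F)cc3)nc2c1` gives 5890 nM. Compound 3 thus carries the lowest number of the three and inhibits growth most strongly: the steps are a 2.2-fold lower number from compound 1 to compound 3 (0.34 log units; beyond the scatter) and a 2.8-fold lower number from compound 2 to compound 3 (0.45 log units; beyond the scatter), both beyond the scatter, whereas a 1.3-fold higher number from compound 1 to compound 2 (0.11 log units; within the scatter) lies within it.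

Compound 4 `COc1ccc(CNc2nc3cc(N)cc(N)c3nc2-c2ccccc2)cc1` has not yet been measured. It differs from compound 3 in one place: methoxy in place of fluoro on an aromatic carbon. The most telling comparison is the step from compound 2 to compound 3, in which two methoxy groups on the same ring were exchanged for a single fluoro and the number fell by a 2.8-fold lower number from compound 2 to compound 3 (0.45 log units; beyond the scatter). Compound 4 puts one methoxy back onto that ring, so the expectation is a rise in this assay, likely not the whole of that gap because a 2.8-fold lower number from compound 2 to compound 3 (0.45 log units; beyond the scatter) involved two methoxy groups. The expected step is a 1.7-fold higher number from compound 3 to compound 4 (0.23 log units; within the scatter). Compound 4 is therefore estimated at 10000 nM, with a range from 4500 nM to 22000 nM.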

Compound 4, concentration for 50% growth inhibition: 28200 nM
Estimate against measurement, compound 4: 2.8-fold (0.45 log units) below; measured number outside the range, above it.
By their numbers in this assay, from the lowest: compound 3; then compounds 1, 2 and 4 (each within the scatter of the next, the first and the last beyond it).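

In this assay, exchanging fluoro for a single methoxy on this ring gives the largest step seen so far (a 4.8-fold higher number from compound 3 to compound 4 (0.68 log units; beyond the scatter)), so one methoxy at this place is enough to lose the whole lead of compound 3. Removing the other methoxy from the ring of compound 2 gives a change that stays within the scatter (a 1.7-fold higher number from compound 2 to compound 4 (0.23 log units; within the scatter)), so among these two compounds the second methoxy makes no readable difference. Compound 4 also lies beyond the scatter of the dichloro compound (a 2.2-fold higher number from compound 1 to compound 4 (0.34 log units; beyond the scatter)), although compounds 1 and 2 do not differ readably from each other, so the 4-methoxyphenyl and 3,4-dichlorophenyl comparisons do not form a simple trend.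

Nothing shown here explains these differences. As far as these compounds go, it remains open whether a plain phenyl, a chloro, a hydroxyl or an amine at this same place would behave like fluoro or like methoxy.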